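The source may report more compounds than this note shows. Statements on the series, on what has been measured and on what is new or still open speak of the compounds shown alone.

Measured so far in a functional assay on MCF7 cells (Homo sapiens) for inhibition, read by sulforhodamine B assay, with a stated time of 48 h, tested at 10 uM; a lower number here means less inhibition, a higher number more inhibition at the concentration tested (going by the name of the read-out):
- compound 1, `O=Cc1ccc(-c2cn3ccnc3c(-c3ccc4ncn(C5CCCCC5)c4c3)n2)cc1`: 47.8%
- compound 2, `Fc1ccccc1-c1cn2ccnc2c(-c2ccc3ncn(C4CCCCC4)c3c2)n1`: 11.2%

Compound 2 stands lowest of the two numbers in this assay; its nearest neighbour is compound 1, which gives 47.8%. Within the data shown here, the only measured step is a number 36.6 percentage points lower from compound 1 to compound 2 (beyond the scatter), brought about by 2-fluorophenyl in place of 4-formylphenyl on an aromatic carbon, and it was large.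

Compound 3, `FC(F)(F)c1cccc(-c2cn3ccnc3c(-c3ccc4ncn(C5CCCCC5)c4c3)n2)c1`, differs from compound 2 by 3-(trifluoromethyl)phenyl in place of 2-fluorophenyl on an aromatic carbon. Among the measured compounds shown here, the one measured step bears on it only in that it changes the same aryl group; no measured pair exchanges 2-fluorophenyl for 3-(trifluoromethyl)phenyl. Since that single step shows the aryl group can move the number a long way, and compound 2 sits at the low end, a step upward beyond the scatter seems the likelier outcome, though its size is poorly defined. For compound 3 an expected a number 16.8 percentage points higher from compound 2 to compound 3 (beyond the scatter) is therefore taken, with the estimate 28% and a range from 5% to 55%.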

Compound 3, a percentage reported as inhibition, at one concentration (the size of the read-out at that concentration, not a potency): 19.9%
The estimate for compound 3 lay 8.1 percentage points above the measured number; measured number inside the range.
By their numbers in this assay, from the lowest: compounds 2 and 3 (each within the scatter of the next); then compound 1.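

In this assay, the exchange of one fluorinated aryl group for another gives a number 8.7 percentage points higher from compound 2 to compound 3 (within the scatter), so this position does not separate 2-fluorophenyl from 3-(trifluoromethyl)phenyl, despite the different substituent and the added fluorine atoms. The second comparison, a number 27.9 percentage points lower from compound 1 to compound 3 (beyond the scatter), shows that the gap to compound 1 is not confined to 2-fluorophenyl: among the three compounds, 4-formylphenyl alone stands apart from the other two aryl groups. No measured evidence accounts for either step.

Going by these compounds, whether the higher number of compound 1 belongs to the formyl group itself or would also appear with other groups on that phenyl ring remains open. A phenyl ring bearing a hydroxymethyl group, a carboxylic acid or an amine would help to settle this.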